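This account rests on a few compounds, and the source may have more. Where it says the series, first, only, none or still open, it means among the compounds named here.

Of the compounds shown here, three have been measured in a physicochemical assay for lipophilicity; on this read-out lower numbers stand for lower lipophilicity and higher numbers for higher lipophilicity. Compound 1, `N=C(N)Nc1cccc(C(=O)NNC(=O)CC(CC(=O)O)c2ccc(F)cc2)c1`, gives 1.28. Compound 2, `N=C(N)Nc1cccc(C(=O)NNC(=O)CC(CC(=O)O)c2ccc(Cl)cc2)c1`, gives 1.68. The step from compound 1 to compound 2 is a number 0.40 log units higher from compound 1 to compound 2 (beyond the scatter), and the structural change behind it is chloro in place of fluoro on an aromatic carbon. Compound 3, `O=C(O)CC(CC(=O)NNC(=O)CCCCNc1ccccn1)c1ccc(F)cc1`, gives 2.23 in this assay, the highest of the three values, and its two neighbours both sit lower by more than the scatter. Compound 3 rests on a different core from compound 1, and the difference between the two cores is not broken down here.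

Compound 4, `O=C(O)CC(CC(=O)NNC(=O)CCCCNc1ccccn1)c1ccc(Cl)cc1`, has not yet been measured. It differs from compound 3 by chloro in place of fluoro on an aromatic carbon, which is the same change that separates compound 1 from compound 2, made at the same place on the aromatic ring. Within the data shown here, the expectation for compound 4 therefore rests on compound 1 and compound 2, whose step of a number 0.40 log units higher from compound 1 to compound 2 (beyond the scatter) is the only measured instance of this change, and the step from compound 3 to compound 4 is estimated at a number 0.40 log units higher from compound 3 to compound 4 (beyond the scatter) in this assay. Compound 4 is accordingly expected to give about 2.63 in this assay, with a likely range from 2.3 to 2.95.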

Compound 4, partition coefficient: 2.63
Compound 4: the middle estimate sits on the measured number at the digits printed; the range from low to high includes it.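

In this assay the change from 4-fluorophenyl to 4-chlorophenyl gives a number 0.40 log units higher from compound 3 to compound 4 (beyond the scatter) on the core of compound 3, which matches at the printed digits the step on the core of compound 1, a number 0.40 log units higher from compound 1 to compound 2 (beyond the scatter) in the same assay. In these two pairs, then, the change carried from one core to the other with its size intact, and neither pair goes against this. Two pairs on two cores do not make a rule for the series, however, and nothing shown explains why the step came out the same on both cores.

The compounds shown leave open whether a third core would give a step of the same size, for instance one with an ester in place of the carboxylic acid or with a shorter chain in place of the one carrying the pyridine ring. They also leave open whether bromo, methyl or trifluoromethyl in place of fluoro would carry from one core to the other as consistently as chloro did in these two pairs.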